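This account rests on a few compounds, and the source may have more. Where it says the series, first, only, none or still open, it means among the compounds named here.

Measured so far in a functional assay on the whole organism (artery, strain albino) with Rattus norvegicus as the target, with a stated time of 60 min, at a dose of 10 mg/kg by the oral route; a lower number here means less inhibition, a higher number more inhibition at the dose given (going by the name of the read-out):
compound 1 `CC1=C(C(=O)Nc2ccc(Br)cc2)C(c2ccc(Cl)cc2Cl)N=C(SCc2ccc(Cl)cc2)N1`, 11.8%
compound 2 `COc1ccc(C2N=C(SCc3ccccc3Cl)NC(C)=C2C(=O)Nc2ccc(Br)cc2)cc1`, 6.7%

Compound 2 lies within the usual scatter of compound 1 in this assay, so these two numbers give no order between them and no trend to build on. Compound 3 `COc1ccc(C2N=C(SCc3ccc(Cl)cc3)NC(C)=C2C(=O)Nc2ccc(Br)cc2)cc1` has not been measured yet. It differs from compound 2 in one place, with the same atoms joined differently: 4-chlorophenyl in place of 2-chlorophenyl on a saturated chain carbon bound to a sulfur. Among the compounds with values here, no pair of measured compounds differs in this place alone; compound 1 and compound 2 differ here and elsewhere at once, so their values show only that both sit low at this dose. With nothing else to go on, the step expected in this assay, a number 2.3 percentage points higher from compound 2 to compound 3 (within the scatter), is not beyond the scatter in either direction. Compound 3 is therefore estimated at 9%, with a range from 0% to 22%.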

Compound 3, a percentage reported as inhibition, in the whole organism at one dose (the size of the read-out at that dose, not a potency): 12.3%
Beside the measured number, compound 3's estimate is 3.3 percentage points below it; the measured number falls inside the stated range.
By their numbers in this assay, from the lowest: compounds 2, 1 and 3 (each within the scatter of the next).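

In this assay, the step of a number 5.6 percentage points higher from compound 2 to compound 3 (within the scatter) comes with 4-chlorophenyl in place of 2-chlorophenyl on a saturated chain carbon bound to a sulfur, so this first single-place reading does not separate the two chlorophenyl isomers at this dose. The step of a number 0.5 percentage points higher from compound 1 to compound 3 (within the scatter) gives a second single-place reading, and 4-methoxyphenyl in place of 2,4-dichlorophenyl on a saturated ring carbon does not separate those compounds either. No measurement at hand offers an explanation for these numbers.

Going by these compounds, all three compounds carry a chlorophenyl group on the saturated chain carbon bound to a sulfur, so it remains open whether a carboxylic acid, an amine or a longer alkyl chain there would move the number beyond the scatter. On the saturated ring carbon, a pyridine ring or a simple cyclohexyl group would test the same question.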